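A few compounds are considered here, and "the series" means these few. Any claim that something is new, unique, unknown or untested is made for them only; others in the source may bear on it.

Of the compounds shown here, two of a shared core have been tested in a functional assay on MGC-803 cells (Homo sapiens) for cytotoxicity, read by MTT assay, with a stated time of 72 h; a lower number here means a stronger inhibitor, a higher number a weaker inhibitor: compound 1, `Cc1cc(Nc2ccc(Cl)cc2)nc(SCc2nc3ccccc3[nH]2)n1`, and compound 2, `COc1ccccc1Nc1cc(C)nc(SCc2nc3ccccc3[nH]2)n1`. In this assay compound 1 gives 28200 nM, and compound 2 gives 56200 nM. Going by the values given here, of the two numbers, compound 2 stands at the higher one, with compound 1 as its only neighbour, and the single measured step, a 2.0-fold higher number from compound 1 to compound 2 (0.30 log units; within the scatter), lies within the scatter, so the two cannot be told apart on these numbers.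

Compound 3, `Cc1cc(Nc2ccc(F)cc2)nc(SCc2nc3ccccc3[nH]2)n1`, has not been measured. It differs from compound 2 in one place: 4-fluorophenyl in place of 2-methoxyphenyl on a nitrogen on an aromatic ring. Among the compounds with values here, the 4-fluorophenyl that enters resembles the 4-chlorophenyl of compound 1 more than the 2-methoxyphenyl that leaves, so the one step that bears on the change, a 2.0-fold higher number from compound 1 to compound 2 (0.30 log units; within the scatter), runs in the opposite direction to the one proposed here, and it was itself within the scatter. No step beyond the scatter is therefore expected.

For compound 3 the expected value in this assay is 32000 nM, with a range from 12000 nM to 85000 nM. The expected step, a 1.8-fold lower number from compound 2 to compound 3 (0.24 log units; within the scatter), is estimated to stay within the scatter.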

Compound 3, half-maximal inhibitory concentration: 5770 nM
Compound 3: middle estimate off by 5.5-fold (0.74 log units), on the high side; the measured number lies below the stated range.
By their numbers in this assay, from the lowest: compound 3; then compounds 1 and 2 (each within the scatter of the next).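

In this assay the group on the nitrogen now proves able to move the number: the earlier pair could not be told apart, but 4-fluorophenyl in place of 2-methoxyphenyl gives a step beyond the scatter (a 9.7-fold lower number from compound 2 to compound 3 (0.99 log units; beyond the scatter)). Even the exchange of one halogen, fluoro in place of chloro on an aromatic carbon, is enough to leave the scatter (a 4.9-fold lower number from compound 1 to compound 3 (0.69 log units; beyond the scatter)), so the similarity between the 4-fluorophenyl and 4-chlorophenyl groups did not carry over to their numbers, and this place on the shared core distinguishes the two halogens. Nothing available here accounts for the difference between fluoro and chloro.

The compounds shown leave open whether the lower number belongs to fluoro itself or would also come with a methyl, a nitrile or a trifluoromethyl group in its place. They also leave open whether the phenyl ring is needed at all, or whether a saturated ring such as cyclohexyl could stand on the same nitrogen.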